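A few compounds are considered here, and "the series" means these few. Any claim that something is new, unique, unknown or untested is made for them only; others in the source may bear on it.

Of the compounds shown here, three sharing one core have been measured in an assay on CHO cells for displacement of a labelled ligand from adenosine receptor A1 (Homo sapiens), read by scintillation counting, tested at 10 uM; on this read-out higher numbers stand for more inhibition at the one concentration tested (going by the name of the read-out) and lower numbers for less inhibition. Compound 1 `CC(C)(C)Cc1c(-c2ccncc2)sc(N)c1C(=O)c1ccc(Cl)cc1` gives 1% in this assay, compound 2 `CC(C)(C)Cc1c(-c2cc(F)ccc2F)sc(N)c1C(=O)c1ccc(Cl)cc1` gives 3% in this assay, and compound 3 `CC(C)(C)Cc1c(-c2ccc(Cl)c(Cl)c2)sc(N)c1C(=O)c1ccc(Cl)cc1` gives 1% in this assay. Compound 3 thus stands level with compound 1 at the digits shown, the two together the lowest of the three numbers, and its furthest neighbour is compound 2, with a number 2 percentage points lower from compound 2 to compound 3 (within the scatter). Every step among the three lies within the scatter: a number 2 percentage points higher from compound 1 to compound 2 (within the scatter) and no change at the digits printed from compound 1 to compound 3 (within the scatter). Compound 4 `COc1ccccc1-c1sc(N)c(C(=O)c2ccc(Cl)cc2)c1CC(C)(C)C` has not yet been measured. It differs from compound 3 in one place: 2-methoxyphenyl in place of 3,4-dichlorophenyl on an aromatic carbon. Among the compounds with values here, the steps that bear on this are the three exchanges of the aryl group on the same aromatic carbon, none of which moved the read-out beyond the scatter. No exchange toward a 2-methoxyphenyl has been measured, so the expectation rests on that flat run, and the step of a number 1 percentage points higher from compound 3 to compound 4 (within the scatter) is expected to stay within the scatter. Compound 4 is therefore estimated at 2%, in the range 0% to 10%.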

Compound 4, a percentage reported as inhibition, at one concentration (the size of the read-out at that concentration, not a potency): 1%
Estimate against measurement, compound 4: 1 percentage points above; the measured number falls inside the stated range.
By their numbers in this assay, from the lowest: compounds 1, 3, 4 and 2 (each within the scatter of the next).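

Placing 2-methoxyphenyl, the only aryl group of the four with an oxygen, on the aromatic carbon next to the ring sulfur leaves this assay flat, with no change at the digits printed from compound 3 to compound 4 (within the scatter), a number 2 percentage points lower from compound 2 to compound 4 (within the scatter) and no change at the digits printed from compound 1 to compound 4 (within the scatter). The flat run at this position therefore now spans pyridin-4-yl, 2,5-difluorophenyl, 3,4-dichlorophenyl and 2-methoxyphenyl, and no group among them stands apart from the others. Nothing available here explains this lack of response.

The compounds shown leave open whether a piperidine or a carboxylic acid on this same carbon would lift the read-out from this level. They also leave open whether a longer chain in place of the neopentyl group, which all four compounds share, would change it.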